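The source may hold more compounds than are shown below. What is called first, only, known or untested is meant among the compounds shown, and "the series" means these compounds.

Series notes. Compound 1 `CCCC[C@@H](/C=C\[C@@H]1OC(=O)C=C[C@@H]1O)OC(C)=O` and compound 2 `CCCC[C@@H](/C=C\[C@@H]1OC(=O)C=C[C@@H]1OC(C)=O)OC(C)=O` share one core and differ only by acetyl in place of hydrogen on an oxygen on a saturated carbon. In a functional assay on HT-1080 cells (Homo sapiens) for cytotoxicity, read by sulforhodamine B assay, with a stated time of 48 h (on this read-out higher numbers stand for an effect only at larger amounts of compound and lower numbers for an effect already at smaller amounts), compound 1 gives 1.8 ug/mL. In this assay compound 2 gives 1.7 ug/mL. The step of a 1.1-fold lower number from compound 1 to compound 2 (0.02 log units; within the scatter) shows that this swap left the read-out unmoved. For the measured compounds named here, compound 2 holds the lower of the two numbers so far, but compound 1 sits within the scatter of it, so no order between them can be claimed.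

Compound 3 `CCCC[C@H](O)/C=C\[C@@H]1OC(=O)C=C[C@@H]1OC(C)=O` is next. Relative to compound 2 the change is hydrogen in place of acetyl on an oxygen on a saturated carbon. Going by the values given here, the only measured step bearing on it is a 1.1-fold lower number from compound 1 to compound 2 (0.02 log units; within the scatter), an acetyl-for-hydrogen swap on an oxygen on a saturated carbon that stayed within the scatter. For compound 3 in this assay no step beyond the scatter is therefore expected, a 1.1-fold higher number from compound 2 to compound 3 (0.02 log units; within the scatter). Compound 3 is estimated at 1.8 ug/mL, with a range of 0.9 ug/mL to 3.6 ug/mL.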

Compound 3, concentration for half-maximal effect: 2.3 ug/mL
Beside the measured number, compound 3's estimate is 1.3-fold (0.11 log units) below it, and the stated range covers the measured number.
By their numbers in this assay, from the lowest: compounds 2, 1 and 3 (each within the scatter of the next).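

Acetoxy to hydroxy at the oxygen on a saturated carbon whose other neighbour is a saturated chain carbon gives a 1.4-fold higher number from compound 2 to compound 3 (0.13 log units; within the scatter) in this assay, so this position, unlike the one changed earlier, also tolerates loss of its acetyl without a change that can be read. With the earlier step of a 1.1-fold lower number from compound 1 to compound 2 (0.02 log units; within the scatter), each of the two oxygens has now been read with acetyl and with hydrogen while the other oxygen carries acetyl, and neither swap leaves the scatter. No evidence at hand gives a reason for this flat response.

From the compounds shown here alone, what hydrogen on both oxygens at once would give remains open. Also open, going by these compounds, is whether a longer acyl chain such as butanoyl, or an amine at this same carbon, would move the number beyond the scatter.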